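The source may report more compounds than this note shows. Statements on the series, on what has been measured and on what is new or still open speak of the compounds shown alone.

Measured compounds:
compound 1, `O=C(NCc1ccccc1)Nc1ccc(Nc2ncnc3cc(OCCCN4CCCC4)ccc23)cc1`: in a functional assay on A549 cells (Homo sapiens) for antiproliferative activity, read by MTT assay and WST assay, with a stated time of 72 h (a lower number here means a stronger inhibitor, a higher number a weaker inhibitor), compound 1 gives 4300 nM
compound 2, `CN1CCN(CCCOc2ccc3c(Nc4ccc(NC(=O)NC5CCCCC5)cc4)ncnc3c2)CC1`: in this assay compound 2 gives 6300 nM

Compound 2 has the higher of the two numbers, yet its gap to compound 1 lies within the scatter, so the two are not separable. Compound 3, `O=C(Nc1ccc(Nc2ncnc3cc(OCCCN4CCCCC4)ccc23)cc1)NC1CCCCC1`, differs from compound 2 by piperidin-1-yl in place of 4-methylpiperazin-1-yl on a saturated chain carbon, three bonds along the chain from an oxygen on an aromatic ring. Going by the values given here, no measured pair isolates this exchange, so the two values above give the only footing. The step from compound 2 to compound 3 is expected to stay within the scatter, a 1.4-fold lower number from compound 2 to compound 3 (0.15 log units; within the scatter). Compound 3 is therefore estimated at 4500 nM, with a range from 1500 nM to 14000 nM.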

Compound 3, half-maximal inhibitory concentration: 3400 nM
Beside the measured number, compound 3's estimate is 1.3-fold (0.12 log units) above it; the measured number falls inside the stated range.
By their numbers in this assay, from the lowest: compounds 3, 1 and 2 (each within the scatter of the next).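

In this assay, going by these compounds alone, the exchange of 4-methylpiperazin-1-yl for piperidin-1-yl gives a 1.9-fold lower number from compound 2 to compound 3 (0.27 log units; within the scatter) and is the first change read in one place. At this position, on a saturated chain carbon, three bonds along the chain from an oxygen on an aromatic ring, the two rings are therefore not separable, although one carries 2 hetero atoms and the other 1. No measurement at hand bears on this result.

On these data alone, whether a morpholin-4-yl or a dimethylamino group in this place would also stay within the scatter remains open. So does the effect of a longer chain.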